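A few compounds are considered here, and "the series" means these few. Any claim that something is new, unique, unknown or untested is made for them only; others in the source may bear on it.

Measured compounds and their values:

compound 1, `CC(=O)c1ccc(NC(=O)C(C(C)C)N(C(=O)c2ccccc2)S(=O)(=O)c2ccc(C)cc2)cc1`: 42.7%
compound 2, `CC(=O)c1ccc(NC(=O)C2CC(O)CN2S(=O)(=O)c2ccc(C)cc2)cc1`: 13%
compound 3, `CC(=O)c1ccc(NC(=O)C(C(C)C)N(C(=O)c2ccccc2)S(=O)(=O)c2ccc([N+](=O)[O-])cc2)cc1`: 27.4%

All three were tested in a functional assay for inhibition, read by spectrophotometry, with a stated time of 20 min, tested at 5 mg/mL; on this read-out lower numbers stand for a weaker effect and higher numbers for a stronger effect at the one concentration tested. Compound 1 gives 42.7%, the highest of the three numbers. Compound 3 differs from compound 1 in one place, (nitro in place of methyl on an aromatic carbon), and this single change brings a number 15.3 percentage points lower from compound 1 to compound 3 (beyond the scatter). Compound 2 gives 13%, the weakest effect in this set, and its steps to compound 3 and to compound 1 both lie beyond the scatter. Compound 2 is built on a different core from compound 1, and the difference between the two cores is not broken down here.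

Compound 4, `CC(=O)c1ccc(NC(=O)C2CC(O)CN2S(=O)(=O)c2ccc([N+](=O)[O-])cc2)cc1`, has not yet been measured. It stands to compound 2 as compound 3 stands to compound 1: nitro in place of methyl on an aromatic carbon. The two place descriptions read the same word for word, so this is the same change on a different core.

Among the compounds with values here, the only guide is the single step seen from compound 1 to compound 3, which lowered the read-out. Applied to compound 2, the expected step is a number 8 percentage points lower from compound 2 to compound 4 (within the scatter), smaller than that earlier one, since the value of compound 2 is already low and the read-out has little room left to fall. On that basis compound 4 is expected to give about 5% in this assay, most likely between 0% and 18%.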

Compound 4, a percentage reported as inhibition, at one concentration (the size of the read-out at that concentration, not a potency): 70.7%
For compound 4 the middle estimate is 65.7 percentage points below the measured one; the whole stated range lies below it.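

In this assay, nitro in place of methyl on an aromatic carbon brings a number 57.7 percentage points higher from compound 2 to compound 4 (beyond the scatter), so on this core the change raises the read-out, while on the core of compound 1 it lowers it, and the two steps clearly differ: the same change on two cores in this assay, a number 15.3 percentage points lower (beyond the scatter) from compound 1 to compound 3 and a number 57.7 percentage points higher (beyond the scatter) from compound 2 to compound 4, 73 percentage points apart, beyond the scatter of two such steps. This shows that in this series the effect of going from 4-methylphenyl to 4-nitrophenyl does not carry from one core to the other, not even in its direction, so a step seen on one core is a poor guide to the same step on another. It does not show why the two cores part ways, and each step rests on a single pair of compounds at one concentration, so it cannot say how the change would behave on any third core.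

The compounds shown leave open whether other groups in the same place, such as an amine or a carboxylic acid, would follow the pattern of nitro or of methyl on each core. Within the data shown here, they also leave open which part of the two cores decides the direction of the step, a question that compounds changed in only one part of the core could answer.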